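Amino to hydroxy on the second core: working notes

The source may hold more compounds than are shown below. What is called first, only, known or untested is meant among the compounds shown, and "the series" means these compounds.

The series is read in a functional assay on HT-29 cells (Homo sapiens) for cytotoxicity, read by sulforhodamine B assay, with a stated time of 72 h; a lower number here means a stronger inhibitor, a higher number a weaker inhibitor. Compound 1 `COc1ccc(/C(F)=C\c2cc(OC)c(OC)c(OC)c2)cc1O` gives 28.9 nM. Compound 3 `COc1ccc(/C(F)=C\c2cc(OC)c(OC)c(OC)c2)cc1N` gives 5 nM in this assay. Compound 2 `COc1ccc(/C(F)=C(/F)c2cc(OC)c(OC)c(OC)c2)cc1N` gives 4.5 nM in this assay; the values of compound 2 and compound 3 lie within the scatter of each other, while compound 1 sits apart from both. How the core of compound 2 differs from the core of compound 3 is not broken down here.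

One single-point change is measured directly. Between compound 3 and compound 1 the change is hydroxy in place of amino on an aromatic carbon, and in this assay it produced a 5.8-fold higher number from compound 3 to compound 1 (0.76 log units; beyond the scatter).

Compound 4 `COc1ccc(/C(F)=C(/F)c2cc(OC)c(OC)c(OC)c2)cc1O` has not yet been measured. It stands to compound 2 as compound 1 stands to compound 3: the change is hydroxy in place of amino on an aromatic carbon. The surroundings of the place are the same word for word in both cases, so this is the same change, carried onto the core of compound 2 rather than that of compound 3. Among the measured compounds shown here, only one measured instance of it exists, so the expectation rests on that one step alone and on the value of compound 2.

The step from compound 2 to compound 4 is expected to be a 5.8-fold higher number from compound 2 to compound 4 (0.76 log units; beyond the scatter) in this assay, taken as a repeat of a 5.8-fold higher number from compound 3 to compound 1 (0.76 log units; beyond the scatter). On that basis compound 4 is estimated at 26 nM, with a range from 10 nM to 70 nM.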

Compound 4, half-maximal inhibitory concentration: 110 nM
Compound 4: middle estimate off by 4.2-fold (0.63 log units), on the low side; the measured number lies above the stated range.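

On the core of compound 2, hydroxy in place of amino gave a 24-fold higher number from compound 2 to compound 4 (1.39 log units; beyond the scatter). In this assay the change therefore keeps its direction on both cores, but its size does not carry over from one core to the other: the same change on two cores in this assay, a 5.8-fold higher number (0.76 log units; beyond the scatter) from compound 3 to compound 1 and a 24-fold higher number (1.39 log units; beyond the scatter) from compound 2 to compound 4, 4.2-fold (0.63 log units) apart, beyond the scatter of two such steps

This shows that a step measured on one core in this series is a reliable guide to the sign of the change on the other, but not to its magnitude, and that the outcome of this swap depends on the core that carries it. It does not show which feature of the cores sets the size of the step, and two pairs are too few to support a rule for any further core.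

The compounds shown leave open how other groups at this place, such as a methylamino group, an acetamido group or a chlorine atom, would behave on the two cores, and whether the gap between the cores would widen, narrow or vanish with them. Also open, as far as these compounds go, is whether the same gap would appear in any read-out other than this assay.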